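Prenyl-to-geranyl extension on the acylphloroglucinol series

The source may report more compounds than this note shows. Statements on the series, on what has been measured and on what is new or still open speak of the compounds shown alone.

Compound 1 `CC(C)=CC[C@@H]1C[C@]2(CC=C(C)C)C(=O)[C@@](CC=C(C)C)(C(=O)C(C(=O)c3ccc(O)c(O)c3)=C2O)C1(C)C` is the reference point of this set. Among the compounds with values here, in a functional assay on HCT-116 cells (Homo sapiens) for inhibition (a higher number here means a weaker inhibitor, a lower number a stronger inhibitor), compound 1 gives 9.22 ug/mL, the only actual number among the values so far. Within the data shown here, compound 2 `CC(C)=CCC/C(C)=C/C[C@]12C[C@@H](CC=C(C)C)C(C)(C)[C@](C/C=C(\C)CCC=C(C)C)(C(=O)C(C(=O)c3ccc(O)c(O)c3)=C1O)C2=O` carries longer chains in more than one place and a differently arranged core, so no single step connects it to compound 1. In this assay compound 2 reaches only a limit, > 20 ug/mL, and no number. That is the limit of > 20 ug/mL in this assay, at which 1 of the 2 values shown sits, one of the two values in hand.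

Compound 3 `CC(C)=CCC/C(C)=C/C[C@@H]1C[C@]2(CC=C(C)C)C(=O)[C@@](CC=C(C)C)(C(=O)C(C(=O)c3ccc(O)c(O)c3)=C2O)C1(C)C` is not yet measured. It differs from compound 1 by 3-methylbut-2-en-1-yl in place of hydrogen on a saturated chain carbon bound to a double-bonded chain carbon.

Among the measured compounds shown here, no measured step of this kind exists in the set, so the direction must be expected rather than read. Given that compound 2, with its extended chains, sits at > 20 ug/mL, a modest loss is expected, with the step of a 1.4-fold higher number from compound 1 to compound 3 (0.15 log units; within the scatter) estimated to lie near the edge of the scatter. For compound 3 in this assay the expected value is 13 ug/mL, within a range from 6 ug/mL to 30 ug/mL.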

Compound 3, half-maximal inhibitory concentration: > 20 ug/mL
Compound 3: no number, only a limit; the forecaster's own chance of this, stated with the estimate: 30%; middle value at least 1.5-fold (0.18 log units) away from the limit.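

Extending the chain with 3-methylbut-2-en-1-yl, on a saturated chain carbon bound to a double-bonded chain carbon, gives 3,7-dimethylocta-2,6-dien-1-yl and provides the only single-place step in this series: in this assay it is an at least 2.1-fold higher number from compound 1 to compound 3 (0.33 log units; beyond the scatter). Compound 2 could not show this, as it differs from compound 1 in more than one place, whereas this loss, beyond the scatter, belongs to one chain extension alone. The size of the loss stays unresolved because compound 3 reaches only a limit, so the step is a bound and not a measured difference: the limit of > 20 ug/mL in this assay, at which 2 of the 3 values shown sit.

Open, going by these compounds, is whether a shorter ethyl chain, or a chain ending in an amine or a carboxylic acid, at this position would retain the activity of compound 1, which gives 9.22 ug/mL. Also open, on these data alone, is whether the same extension to 3,7-dimethylocta-2,6-dien-1-yl on only one of the other 3-methylbut-2-en-1-yl chains of the shared core would carry a similar cost.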